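The source may hold more compounds than are shown below. What is called first, only, known or untested is meant among the compounds shown, and "the series" means these compounds.

Three compounds have been measured in an assay on membranes from brain for displacement of a labelled ligand from Neuronal acetylcholine receptor; alpha4/beta2 (Rattus norvegicus); on this read-out higher numbers stand for weaker inhibition and lower numbers for stronger inhibition:
compound 1 `Cc1ncccc1OC[C@@H]1CCCN1C`, 22.9 nM
compound 2 `CN1CCC[C@H]1COc1cccnc1Br`, 451 nM
compound 3 `CN1CCC[C@H]1COc1cncc(Br)c1`, 0.27 nM

Compound 3 stands lowest of the three in this assay, with compound 1 nearer to it and compound 2 farthest. Compound 2 and compound 3 hold the same atoms joined differently; how their cores differ is not broken down here. From compound 2 to compound 1 the change is methyl in place of bromo on an aromatic carbon, and it gave a 20-fold lower number from compound 2 to compound 1 (1.29 log units; beyond the scatter). Compound 4 `Cc1cncc(OC[C@@H]2CCCN2C)c1`, not yet measured, arises from compound 3 by methyl in place of bromo on an aromatic carbon. This is the same kind of change, but here it sits two atoms from the ring nitrogen and meta to the group of 8 heavy atoms, whereas in compound 1 it sits next to the ring nitrogen and ortho to that group. Resting on the earlier exchange, which produced a 20-fold lower number from compound 2 to compound 1 (1.29 log units; beyond the scatter) at another place, and on compound 3 giving 0.27 nM, the expected step is a 5.6-fold higher number from compound 3 to compound 4 (0.74 log units; beyond the scatter). Compound 4 is estimated at 1.5 nM, between 0.3 nM and 8 nM.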

Compound 4, inhibition constant: 0.48 nM
For compound 4 the middle estimate is 3.1-fold (0.49 log units) above the measured one, within the range that was stated.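

Exchanging bromo for methyl did not read the same on the two cores in this assay: the same change on two cores in this assay, a 20-fold lower number (1.29 log units; beyond the scatter) from compound 2 to compound 1 and a 1.8-fold higher number (0.25 log units; within the scatter) from compound 3 to compound 4, 35-fold (1.54 log units) apart, beyond the scatter of two such steps

On the core of compound 3 the exchange gave a 1.8-fold higher number from compound 3 to compound 4 (0.25 log units; within the scatter), so methyl and bromo cannot be told apart at this place, two atoms from the ring nitrogen. The two steps do not show whether the place of the group, the rest of the core or both account for the gap, and two pairs give no rule for other cores.

On these data alone, it stays open how an amine or a nitrile in place of bromo would read at either place. As far as these compounds go, a longer chain such as ethyl in place of methyl remains equally open.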